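A few compounds are considered here, and "the series" means these few. Any claim that something is new, unique, unknown or untested is made for them only; others in the source may bear on it.

Working notes on the series. Compound 1 `CC(=O)N1CCN(S(=O)(=O)c2ccc(F)cc2)C(C)C1` and compound 2 `CC(=O)N1CCN(S(=O)(=O)c2ccc(F)cc2)CC1C` share one core and differ only in where a methyl sits on the saturated ring. In a functional assay on the whole organism with Mus musculus as the target, with stated times of 24 h and 20 min (a higher number here means that more compound is needed for the effect, a lower number that less compound is needed), compound 1 gives 0.1 mg/kg. In this assay compound 2 gives 1 mg/kg, the highest of the two numbers shown, and the gap between compound 1 and compound 2 lies beyond the usual scatter. Compound 3 `CC(=O)N1CCN(S(=O)(=O)c2ccc(F)cc2)CC1c1ccccc1` is not yet measured. It differs from compound 2 in one place: phenyl in place of methyl on a saturated ring carbon. Within the data shown here, no step between two measured compounds tells how this change behaves, so the expectation rests only on the two numbers at hand. The step from compound 2 is expected to be small, either way, or none beyond the scatter: a 2.0-fold higher number from compound 2 to compound 3 (0.30 log units; within the scatter). For compound 3 the estimate in this assay is 2 mg/kg, with a range from 0.5 mg/kg to 10 mg/kg.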

Compound 3, minimum effective dose: > 10 mg/kg
Compound 3 ended at the assay's limit; the forecaster's own chance of this, stated with the estimate: 15%; middle value at least 5.0-fold (0.69 log units) from the limit.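

Phenyl in place of methyl on this saturated ring carbon, next to the ring nitrogen, gives an at least 10-fold higher number from compound 2 to compound 3 (1.00 log units; beyond the scatter) in this assay, so the position that carries methyl in compound 2 does not accept every group, which methyl alone could not show. Compound 3 sits at a limit of the assay, > 10 mg/kg, and that figure is a limit and not a number. The step therefore marks a floor and not a measured size: the limit of > 10 mg/kg in this assay, at which 1 of the 3 values shown sits.

From the compounds shown here alone, how far compound 3 lies past that limit stays unknown, as does what sets the step apart, the ring or only the added carbons. An ethyl or a cyclohexyl group on the same carbon would separate these two readings, and phenyl on the methyl-bearing carbon of compound 1 remains an open case as well.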